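The source may report more compounds than this note shows. Statements on the series, on what has been measured and on what is new or still open speak of the compounds shown alone.

In a physicochemical assay for lipophilicity (on this read-out higher numbers stand for higher lipophilicity and lower numbers for lower lipophilicity), three compounds have been measured:

compound 1 `c1ccc(Oc2ccccc2C2=NC(c3ccccc3)CO2)cc1` gives 5.61
compound 2 `Fc1cccc(F)c1C1=NC(c2ccccc2)CO1` gives 3.01
compound 3 `O=[N+]([O-])c1ccccc1-c1ncco1` gives 1.27

Compound 1 stands highest of the three numbers. Its nearest neighbour is compound 2, whose value lies well beyond the scatter below it, and compound 3 lies furthest away, lower still by a wide margin. No two of these compounds differ in only one place, so no single-point step between measured compounds can be read from them; the account therefore rests on the values alone.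

The unmeasured compound 4 `CSc1ccccc1C1=NC(c2ccccc2)CO1` is reached from compound 1 by one change: methylsulfanyl in place of phenoxy on an aromatic carbon. Compound 4 keeps the core of compound 1 and the ring that carries it; only the group on that aromatic carbon is exchanged.

For the measured compounds named here, since no measured pair shows this exchange, the size of the step can only be anticipated. In this assay a step from compound 1 to compound 4 that is expected to be downward and beyond the scatter amounts to a number 1.41 log units lower from compound 1 to compound 4 (beyond the scatter). Compound 4 is accordingly expected to give about 4.2, within a range from 3.7 to 4.7.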

Compound 4, partition coefficient: 3.5
Compound 4: middle estimate off by 0.70 log units, on the high side; measured number below the stated range.
By their numbers in this assay, from the lowest: compound 3; then compound 2; then compound 4; then compound 1.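

In this assay, for the compounds shown here, methylsulfanyl in place of phenoxy on this aromatic carbon, ortho to a large group, gives a number 2.11 log units lower from compound 1 to compound 4 (beyond the scatter), the first step that can be read for a change in one place. Going by these compounds alone, the read-out at this position therefore responds strongly to the group it carries, and this is something the earlier compounds, which differ in more than one place, could not show. The change takes away seven heavy atoms with a six-membered aromatic ring and brings in two heavy atoms with no ring, while the counts of hydrogen-bond donors and acceptors and the net charge stay the same; nothing measured here accounts for the size of the step.

The compounds shown leave open how much of the step goes with the aromatic ring that leaves and how much with the sulfur that replaces oxygen, a question that a methoxy or a phenylsulfanyl group on the same carbon would address. Also open, going by these compounds, is how the read-out would respond to an amine or a carboxylic acid at this position.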